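Acetyl for benzoyl on a chalcone anilide

The compounds below may be only part of what the source reports. "The series", "measured", "known", "first", "only" and "open" are said of these compounds alone.

Three chalcone anilides have been measured in a functional assay on HUVEC cells (Homo sapiens) for inhibition, tested at 10 ug/mL; a higher number here means a stronger effect of the compound at the concentration tested, a lower number a weaker effect. Compound 1 `COc1cc(/C=C/C(=O)c2cccc(NC(=O)c3ccccc3)c2)ccc1O` gives 69% and stands second highest of the three. Compound 2 `COc1cc(/C=C/C(=O)c2cccc(NC(=O)c3cc(Cl)cc(Cl)c3)c2)ccc1O` gives 58%, and compound 3 `CCCC(=O)Nc1cccc(C(=O)/C=C/c2ccc(O)c(OC)c2)c1` gives 87%, the highest number of the set. The move from compound 1 to compound 2 was a number 11 percentage points lower from compound 1 to compound 2 (beyond the scatter), whereas the move to compound 3 was a number 18 percentage points higher from compound 1 to compound 3 (beyond the scatter), and between the two substituted amides the step was a number 29 percentage points higher from compound 2 to compound 3 (beyond the scatter).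

Compound 4 `COc1cc(/C=C/C(=O)c2cccc(NC(C)=O)c2)ccc1O` has not yet been measured. It differs from compound 1 by methyl in place of phenyl on a carbonyl carbon. The step that bears most directly on it is the replacement of the same phenyl by propyl, which raised the read-out from compound 1 to compound 3 by a number 18 percentage points higher from compound 1 to compound 3 (beyond the scatter); methyl is likewise a plain alkyl group in that position. A rise beyond the scatter is therefore expected, and the expected step from compound 1 to compound 4 in this assay is a number 11 percentage points higher from compound 1 to compound 4 (beyond the scatter). Compound 4 is accordingly estimated at 80%, with a range from 66% to 92%.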

Compound 4, a percentage reported as inhibition, at one concentration (the size of the read-out at that concentration, not a potency): 32%
Estimate against measurement, compound 4: 48 percentage points above; measured number outside the range, below it.
By their numbers in this assay, from the lowest: compound 4; then compound 2; then compound 1; then compound 3.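

In this assay a plain alkyl group on this carbonyl carbon does not by itself raise the read-out, since methyl in place of phenyl gives a number 37 percentage points lower from compound 1 to compound 4 (beyond the scatter) and so runs opposite to the propyl step. The length of the chain therefore carries weight here, with hydrogen in place of ethyl on the saturated chain carbon giving a number 55 percentage points lower from compound 3 to compound 4 (beyond the scatter) and the two alkyl amides taking the two ends of the set. The aryl amides lie between them, and even the 3,5-dichlorophenyl amide is left above methyl, as a number 26 percentage points lower from compound 2 to compound 4 (beyond the scatter) shows.

Nothing available accounts for the gap between methyl and propyl. From the compounds shown here alone, whether an ethyl group falls nearer methyl or propyl, and whether a longer chain such as butyl or hexyl keeps the read-out high, stays open.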